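Replacing tert-butyl with octyl on the shared core

A few compounds are considered here, and "the series" means these few. Any claim that something is new, unique, unknown or untested is made for them only; others in the source may bear on it.

In a functional assay on the whole organism with Scenedesmus acutus as the target (on this read-out lower numbers stand for stronger inhibition and higher numbers for weaker inhibition), compound 1 (`CC(C)COC(=O)c1cc(N2C(=O)C3=C(CCCC3)C2=O)ccc1Cl`) gives 759 nM, while compound 2 (`CC(C)(C)OC(=O)c1cc(N2C(=O)C3=C(CCCC3)C2=O)ccc1Cl`) gives 12900 nM, the higher of the two numbers and so the weaker inhibition. Compound 3 (`CCCCCCCCOC(=O)c1cc(N2C(=O)C3=C(CCCC3)C2=O)ccc1Cl`) has not yet been measured. It carries octyl in place of tert-butyl on an oxygen next to a carbonyl group. For the measured compounds named here, only one measured step bears on this change, the large one at the same place, where tert-butyl took the place of isobutyl: a 17-fold higher number from compound 1 to compound 2 (1.23 log units; beyond the scatter). Going by the values given here, removing tert-butyl might therefore undo much of that step in this assay, although no measured compound shows what an octyl chain does, so the uncertainty is wide. A fall beyond the scatter is expected, with an estimated 8.6-fold lower number from compound 2 to compound 3 (0.93 log units; beyond the scatter). The expected value for compound 3 is 1500 nM, within an estimated range of 300 nM to 7000 nM.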

Compound 3, half-maximal inhibitory concentration: > 100000 nM
Compound 3: a limit, no number; the forecaster's own chance of this, stated with the estimate: 3%; middle value at least 66-fold (1.82 log units) from the limit.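

Compound 3 gives a limit and not a number in this assay: the limit of > 100000 nM in this assay, at which 1 of the 3 values shown sits. Before this result, the only change on this oxygen next to a carbonyl group was from isobutyl to tert-butyl, which left open whether an unbranched chain might recover inhibition, but octyl in place of tert-butyl gives an at least 7.7-fold higher number from compound 2 to compound 3 (0.88 log units; beyond the scatter). Set against the isobutyl ester, the same chain gives an at least 130-fold higher number from compound 1 to compound 3 (2.11 log units; beyond the scatter), so isobutyl remains the only one of the three groups with a value well clear of the other two.

The compounds shown leave open how inhibition changes with chain length between these groups, as with a butyl or hexyl chain on this oxygen. They also leave open whether a cyclohexyl or benzyl group here, or a carboxylic acid in place of the ester, would keep the inhibition seen with compound 1.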